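Benzylamine pKa series: 4-aminoquinoline side chain variants

The compounds below may be only part of what the source reports. "The series", "measured", "known", "first", "only" and "open" are said of these compounds alone.

Measured compounds in a physicochemical assay for acid dissociation:
compound 1, `COc1cccc(CNCCCNc2ccnc3cc(Oc4ccccc4)ccc23)c1O`: 9.28
compound 2, `COc1cccc(CNCCCNc2ccnc3cc(-c4cc(C(F)(F)F)cc(C(F)(F)F)c4)ccc23)c1O`: 9.47
compound 3, `COc1ccc(F)cc1CNCCCNc1ccnc2cc(Oc3ccccc3)ccc12`: 9.28

Compound 1 and compound 3 share a core and differ by 5-fluoro-2-methoxyphenyl in place of 2-hydroxy-3-methoxyphenyl on a saturated chain carbon bound to an amine nitrogen. Between them, no change at the digits printed from compound 1 to compound 3 (within the scatter). Compound 2 carries a different core; how the core of compound 2 differs from the core of compound 1 is not broken down here. Its value sits nearest to compound 1 and within the scatter of both others, so no order among the three is claimed.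

Compound 4, `COc1ccc(F)cc1CNCCCNc1ccnc2cc(-c3cc(C(F)(F)F)cc(C(F)(F)F)c3)ccc12`, is not yet measured. It differs from compound 2 by 5-fluoro-2-methoxyphenyl in place of 2-hydroxy-3-methoxyphenyl on a saturated chain carbon bound to an amine nitrogen, the same change already seen from compound 1 to compound 3. Because no change at the digits printed from compound 1 to compound 3 (within the scatter), the step of no change at the digits printed from compound 2 to compound 4 (within the scatter) is expected to be of the same negligible size. Compound 4 is therefore expected at 9.47 in this assay.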

Compound 4, acid dissociation constant: 9.47
Compound 4: middle estimate and measured number agree at the digits printed; the range from low to high includes it.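

In this assay, 5-fluoro-2-methoxyphenyl in place of 2-hydroxy-3-methoxyphenyl gives no change at the digits printed from compound 2 to compound 4 (within the scatter) on one core and no change at the digits printed from compound 1 to compound 3 (within the scatter) on the other. The change therefore carries over between these two cores with no step beyond the scatter, although this rests on just two pairs, neither of which goes against it. This does not show that the change would stay as small on any further core, and no measurement shown bears on why the value holds.

For the compounds shown here, the single swap leaves the separate contributions of the hydroxy and fluoro parts of the change unresolved. Also open, from the compounds shown here alone, is how the read-out would respond to a carboxylic acid on the benzyl ring, or to a longer chain in place of the present one.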